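The compounds below may be only part of what the source reports. "The series", "measured", "known", "first", "only" and "open" are said of these compounds alone.

Compound 2 `CCN1CCN(c2cccc3c2CN([C@H](CCCNc2cncc(OC)n2)c2ccc(OC)c(OC)c2)C3=O)CC1` gives 4 nM in a functional assay on CHO-K1 cells for antagonist activity at Urotensin-2 receptor (Rattus norvegicus), read by FLIPR and calcium flux, with a stated time of 1 h (a higher number here means a weaker inhibitor, a lower number a stronger inhibitor), a number that sits within the scatter of compound 1 `CCN1CCN(c2cccc3c2CN([C@H](CCCN(C)S(=O)(=O)c2cccs2)c2ccc(OC)c(OC)c2)C3=O)CC1`, which gives 7 nM. For the measured compounds named here, the only measured step, a 1.8-fold lower number from compound 1 to compound 2 (0.24 log units; within the scatter), altered the same end of the chain and did not move the number beyond the scatter. Compound 3 `CCN1CCN(c2cccc3c2CN([C@H](CCCNS(=O)(=O)c2c[nH]cn2)c2ccc(OC)c(OC)c2)C3=O)CC1` carries (1H-imidazol-4-yl)sulfonyl in place of 6-methoxypyrazin-2-yl on an amine nitrogen. Because that earlier step a 1.8-fold lower number from compound 1 to compound 2 (0.24 log units; within the scatter) was small, the expected change here is also small, and a 2.0-fold higher number from compound 2 to compound 3 (0.30 log units; within the scatter) is what is expected. Compound 3 is therefore estimated at 8 nM, with a range from 3 nM to 25 nM.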

Compound 3, half-maximal inhibitory concentration: 23 nM
Compound 3: the middle estimate sits 2.9-fold (0.46 log units) below what was measured; the measured number falls inside the stated range.
By their numbers in this assay, from the lowest: compounds 2 and 1 (each within the scatter of the next); then compound 3.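

Swapping 6-methoxypyrazin-2-yl for (1H-imidazol-4-yl)sulfonyl on the amine nitrogen gives a 5.8-fold higher number from compound 2 to compound 3 (0.76 log units; beyond the scatter) in this assay and is the first change at this end of the chain to pass the scatter. The second comparison, with a 3.3-fold higher number from compound 1 to compound 3 (0.52 log units; beyond the scatter) for the swap to ((1H-imidazol-4-yl)sulfonyl)amino, also passes it, so this position does not treat all these groups alike. Nothing available explains the shift. Still open, going by these compounds, is whether the sulfonyl link or the imidazole ring carries the difference, and a phenylsulfonyl group on the same amine nitrogen would help separate the two.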